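This account rests on a few compounds, and the source may have more. Where it says the series, first, only, none or still open, it means among the compounds named here.

Of the compounds shown here, two built on one shared core have been tested in a functional assay on SF-268 cells (Homo sapiens) for antiproliferative activity, read by MTT assay, with a stated time of 96 h; on this read-out higher numbers stand for weaker inhibition and lower numbers for stronger inhibition. Compound 1 `CCc1ccc(N2C(=O)NC3(CSC4=C3C(=O)c3ncccc3C4=O)C2=O)cc1` gives 450 nM in this assay. Compound 2 `O=C1NN(c2ccccc2)C(=O)C2(CSC3=C2C(=O)c2ncccc2C3=O)N1` gives 2200 nM in this assay. Of these two numbers compound 1 stands lowest, and its distance from compound 2 lies beyond the usual scatter of repeated measurements, so compound 1 is the stronger inhibitor of the pair.

Compound 3 `CC(C)(C)c1ccc(N2C(=O)NC3(CSC4=C3C(=O)c3ncccc3C4=O)C2=O)cc1` has not yet been measured. It differs from compound 1 in a single place: tert-butyl in place of ethyl on an aromatic carbon. The core and the rest of the molecule stay as they are. For the measured compounds named here, no pair of measured compounds shows what such an exchange does here, so the size of the step is open. The expected step is a 1.1-fold higher number from compound 1 to compound 3 (0.05 log units; within the scatter), small and with no clear direction beyond the scatter. Compound 3 is therefore estimated at 500 nM, with a likely range from 200 nM to 1300 nM.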

Compound 3, half-maximal inhibitory concentration: 500 nM
The estimate for compound 3 equals the measured number at the digits printed; the range from low to high includes it.
By their numbers in this assay, from the lowest: compounds 1 and 3 (each within the scatter of the next); then compound 2.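

In this assay, putting tert-butyl in place of ethyl on the aromatic ring gives a 1.1-fold higher number from compound 1 to compound 3 (0.05 log units; within the scatter). For the compounds shown here, this is the first direct reading of a change at this position, para to a large group: a substituent of 4 carbons and one of 2 carbons give numbers that cannot be told apart, so the extra carbons bring neither a measurable gain nor a measurable loss here. Nothing measured among these compounds explains why the two groups read alike.

The compounds shown cover only these two hydrocarbon groups, so it stays open whether this position would accept a group of a different kind, such as an amine or a carboxylic acid. As far as these compounds go, it is equally open whether a longer chain, or plain hydrogen in place of the group, would keep the number in the same range.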